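The compounds below may be only part of what the source reports. "The series", "measured", "known", "first", "only" and "open" are said of these compounds alone.

Compound 2 `COc1cc(-c2nc(SCc3cn(Cc4ccccc4Cl)nn3)nc(Nc3ccc(C)cc3)c2C#N)cc(OC)c1OC` gives 5850 nM in a functional assay on ECa-109 cells (Homo sapiens) for inhibition, read by MTT assay, with a stated time of 72 h; a lower number here means a stronger inhibitor, a higher number a weaker inhibitor. Compound 1 `Cc1ccc(Nc2nc(SCc3cn(Cc4ccccc4Cl)nn3)nc(-c3ccc(C(C)C)cc3)c2C#N)cc1` gives 5080 nM in this assay, and the two numbers lie within the scatter of each other, so compound 2 stands beside compound 1 rather than apart from it. For the measured compounds named here, the one measured step, a 1.2-fold higher number from compound 1 to compound 2 (0.06 log units; within the scatter), changed the same aryl group. Compound 3 `Cc1ccc(Nc2nc(SCc3cn(Cc4ccccc4Cl)nn3)nc(-c3ccc(Cl)cc3)c2C#N)cc1` is not yet measured and differs from compound 2 in one place: 4-chlorophenyl in place of 3,4,5-trimethoxyphenyl on an aromatic carbon. Since that earlier aryl swap stayed within the scatter, no shift beyond the scatter is expected: a 1.2-fold lower number from compound 2 to compound 3 (0.07 log units; within the scatter). Compound 3 is thus estimated at 5000 nM, between 2000 nM and 12000 nM.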

Compound 3, half-maximal inhibitory concentration: 7540 nM
Compound 3: the middle estimate sits 1.5-fold (0.18 log units) below what was measured; the measured number falls inside the stated range.
By their numbers in this assay, from the lowest: compounds 1, 2 and 3 (each within the scatter of the next).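

In this assay, the 4-chlorophenyl group joins the two earlier aryl groups without separating from them: the swap from 3,4,5-trimethoxyphenyl gives a 1.3-fold higher number from compound 2 to compound 3 (0.11 log units; within the scatter), and chloro in place of isopropyl gives a 1.5-fold higher number from compound 1 to compound 3 (0.17 log units; within the scatter). So at this position, next to the ring nitrogen, three differently substituted phenyl groups cannot be told apart, whether they carry hydrogen-bond acceptors or none. Nothing available explains this flat result. Still open, going by these compounds, is whether an amine or a carboxylic acid on this phenyl ring would move the number beyond the scatter.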